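The source may hold more compounds than are shown below. What is called first, only, known or untested is meant among the compounds shown, and "the series" means these compounds.

Of the compounds shown here, three built on one shared core have been tested in an ADME assay on MT4 cells (Homo sapiens) for cytotoxicity, read by MTT assay, with a stated time of 5 days; on this read-out lower numbers stand for higher toxicity in this test and higher numbers for lower toxicity in this test. There, compound 1 (`Cc1cc(C)cc(S(=O)(=O)c2c(C(=O)N[C@@H]3CCN(CC(N)=O)C3)[nH]c3ccc(Cl)cc23)c1`) gives 31000 nM, compound 2 (`Cc1cc(C)cc(S(=O)(=O)c2c(C(=O)N[C@H]3CCN(S(C)(=O)=O)C3)[nH]c3ccc(Cl)cc23)c1`) gives 29900 nM and compound 3 (`Cc1cc(C)cc(S(=O)(=O)c2c(C(=O)N[C@H]3CCN(CC(N)=O)C3)[nH]c3ccc(Cl)cc23)c1`) gives 28100 nM. Compound 3 therefore stands level with the other two, all within the usual scatter of repeated measurements.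

The next compound to be tested is compound 4 (`CCS(=O)(=O)NC(=O)c1[nH]c2ccc(Cl)cc2c1S(=O)(=O)c1cc(C)cc(C)c1`). Its difference from compound 3 is ethylsulfonyl in place of 1-(carbamoylmethyl)pyrrolidin-3-yl on an amide-type nitrogen. In plain terms, ethylsulfonyl takes the place of the whole 1-(carbamoylmethyl)pyrrolidin-3-yl group, so the ring and the defined stereocentre both leave.

Among the compounds with values here, three measured steps bear on this change. The step of a 1.0-fold lower number from compound 1 to compound 2 (0.02 log units; within the scatter) exchanged groups on the same amide-type nitrogen. The step of a 1.1-fold lower number from compound 2 to compound 3 (0.03 log units; within the scatter) exchanged groups on an amine nitrogen in a ring. The step of a 1.1-fold lower number from compound 1 to compound 3 (0.04 log units; within the scatter) comes with the fact that compounds 1 and 3 differ only in the configuration as drawn. All three stayed within the scatter, but none of them removes the ring, so the new change is larger than anything yet tested.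

On this basis, no shift beyond the scatter is expected in either direction, and the estimated step is a 1.1-fold higher number from compound 3 to compound 4 (0.03 log units; within the scatter). The expected value for compound 4 is 30000 nM, with an estimated range from 12000 nM to 80000 nM.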

Compound 4, half-maximal cytotoxic concentration: > 283000 nM
Compound 4: a limit, no number; the forecaster's own chance of this, stated with the estimate: 25%; at least 9.4-fold (0.97 log units) between middle value and limit.
By their numbers in this assay, from the lowest: compounds 3, 2 and 1 (each within the scatter of the next). At a limit, above all of these: compound 4.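

Compound 4 gives > 283000 nM in this assay, and this is a limit of the assay, not a number. The limit still lets the change be read against each earlier compound, as an at least 10-fold higher number from compound 3 to compound 4 (1.00 log units; beyond the scatter), as an at least 9.4-fold higher number from compound 2 to compound 4 (0.97 log units; beyond the scatter) and as an at least 9.1-fold higher number from compound 1 to compound 4 (0.96 log units; beyond the scatter), so replacing either substituted pyrrolidin-3-yl group on the amide-type nitrogen with ethylsulfonyl gives lower toxicity in this test. Among the earlier compounds, neither the exchange of groups on the ring nitrogen nor the drawn configuration moved the number beyond the scatter, so this is the first change shown that does, and it alters the whole group on the amide-type nitrogen rather than only a part of it.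

The compounds shown cannot separate the loss of the ring from the arrival of the ethylsulfonyl group, and a plain ethyl group or a longer propylsulfonyl chain on the same nitrogen would help tell these two apart. The limit also leaves open how large the step really is, and nothing shown explains why the number moves.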